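Working notes: the bare aryl amine of this core series

The source may report more compounds than this note shows. Statements on the series, on what has been measured and on what is new or still open speak of the compounds shown alone.

Measured so far:
- compound 1 `O=[N+]([O-])c1cc(Nc2nc3nonc3nc2O)ccc1OC(F)(F)F`: 53500 nM
- compound 2 `CCCCOc1cccc(Nc2nc3nonc3nc2O)c1`: 2300 nM
- compound 3 `Oc1nc2nonc2nc1Nc1ccc(OCCCC(F)(F)F)c(F)c1`: 4200 nM

Three compounds on the shared core have been run in an assay on mitochondria from L6 cells (Rattus norvegicus) for activation, with a stated time of 90 min; on this read-out higher numbers stand for an effect only at larger amounts of compound and lower numbers for an effect already at smaller amounts. Compound 1 gives 53500 nM in this assay. Compound 2 gives 2300 nM, the lowest of the three numbers. Compound 3 gives 4200 nM; its value and that of compound 2 lie within the scatter of each other, so no order between these two can be read. Compound 1 stands apart from compound 2 by a gap beyond the scatter.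

Compound 4 `Oc1nc2nonc2nc1Nc1ccccc1` is the next to be measured. It differs from compound 2 in one place: hydrogen in place of butoxy on an aromatic carbon. Among the measured compounds shown here, no pair of measured compounds isolates this change, so the expectation rests only on the spread of the three values shown. Stripping the ring of its only substituent is expected to move the number upward, and the step from compound 2 to compound 4 is estimated at a 5.2-fold higher number from compound 2 to compound 4 (0.72 log units; beyond the scatter), beyond the scatter. Compound 4 is therefore expected to come in near 12000 nM, within a range from 3000 nM to 45000 nM.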

Compound 4, half-maximal effective concentration: 66700 nM
For compound 4 the middle estimate is 5.6-fold (0.74 log units) below the measured one, outside the stated range (above it).
By their numbers in this assay, from the lowest: compounds 2 and 3 (each within the scatter of the next); then compounds 1 and 4 (each within the scatter of the next).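

Hydrogen in place of butoxy on an aromatic carbon gives a 29-fold higher number from compound 2 to compound 4 (1.46 log units; beyond the scatter) in this assay, a large step beyond the scatter. Among the compounds shown here, this is the one step so far that isolates a single change on the aromatic ring, and it shows that the read-out at this position depends strongly on the substituent: with butoxy present, the effect appears at much smaller amounts of compound. For the compounds shown here, no measurement on hand says why the loss of this group moves the number so far.

On these data alone, it remains open whether the step follows the ether oxygen or the four carbons of the butoxy chain, and a methoxy group or a longer alkoxy chain on the same carbon would help separate the two. Also open, as far as these compounds go, is how an amine or a carboxylic acid would read at this position.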